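Trifluoromethyl on the acid ring of compound 1

A few compounds are considered here, and "the series" means these few. Any claim that something is new, unique, unknown or untested is made for them only; others in the source may bear on it.

compound 1 `O=C(O)c1cc(-n2c(-c3ccccc3)cc3c2CCCC3)ccc1O` — >= 60%
compound 2 `COC(=O)c1cc(-n2c(-c3ccccc3)cc3c2CCCC3)ccc1O` — 0%

Both were run in a functional assay on the whole organism (strain Wistar) for inhibition, with Rattus norvegicus as the target, read by paw edema, with stated times of 30 min and 3 h, at a dose of 200 mg/kg by the oral route; on this read-out higher numbers stand for more inhibition at the one dose given (going by the name of the read-out) and lower numbers for less inhibition. Compound 1 gives only a limit, >= 60%, not a number. Compound 2 gives 0%. Among the compounds with values here, the single measured step, a number at least 60 percentage points lower from compound 1 to compound 2 (beyond the scatter), concerns the acid itself, and one of the two values sits at the limit of >= 60% in this assay, at which 1 of the 2 values shown sits. Within the data shown here, compound 3 `O=C(O)c1cc(-n2c(-c3ccccc3)cc3c2CCCC3)c(C(F)(F)F)cc1O` differs from compound 1 by trifluoromethyl in place of hydrogen on an aromatic carbon, keeping the carboxy group; no measured step covers a change of that kind. Compound 3 is expected to stay close to compound 1, a number at least 5 percentage points lower from compound 1 to compound 3 (that floor lies within the scatter). The estimate for compound 3 is 55%, from 30% to 80%.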

Compound 3, a percentage reported as inhibition, in the whole organism at one dose (the size of the read-out at that dose, not a potency): 0%
Compound 3: the middle estimate sits 55 percentage points above what was measured, outside the stated range (below it).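

In this assay, trifluoromethyl on the aromatic carbon para to a carboxy group and ortho to a large group gives a number at least 60 percentage points lower from compound 1 to compound 3 (beyond the scatter), with the carboxy and hydroxy groups unchanged. Keeping the carboxy group is therefore not enough for inhibition at this dose, and the read-out also depends on this ring position, where the earlier pair showed a change only at the acid. The size of the step is a bound, not an exact difference: the limit of >= 60% in this assay, at which 1 of the 3 values shown sits.

Open, from the compounds shown here alone, is whether fluorine, methyl or an amine on this aromatic carbon behaves like hydrogen or like trifluoromethyl. The compounds shown give no cause for the loss.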